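This account rests on a few compounds, and the source may have more. Where it says the series, first, only, none or still open, it means among the compounds named here.

- Compound 1 `COc1cc2nccc(Oc3ccc(Nc4nn(C)cc4C(=O)N4CCCCC4)cc3)c2cc1C(N)=O`: 5650 nM
- Compound 2 `COc1cc2nccc(Oc3ccc(Nc4nn(C)cc4C(=O)NCC(C)C)cc3)c2cc1C(N)=O`: > 10000 nM

In a functional assay on BaF3 cells (Mus musculus) for antiproliferative activity, read by CCK-8 assay and cell counting, with a stated time of 76 h (a lower number here means a stronger inhibitor, a higher number a weaker inhibitor), compound 1 gives 5650 nM. Compound 2 reads > 10000 nM, which is a limit of the assay and not a number, and so it stands at the limit of > 10000 nM in this assay, at which 1 of the 2 values shown sits.

Compound 3 `COc1cc2nccc(Oc3ccc(Nc4nn(C)cc4C(=O)Nc4cccc(F)c4)cc3)c2cc1C(N)=O` has 3-fluorophenyl in place of isobutyl on an amide-type nitrogen. Going by the values given here, one measured step bears on this, a change on the same carbonyl carbon: an at least 1.7-fold higher number from compound 1 to compound 2 (0.24 log units; that floor lies within the scatter). Among the compounds with values here, no measured compound has an aromatic ring on that amide nitrogen, so this guide is weak. Within the data shown here, the only number to lean on is compound 1 at 5650 nM. In this assay, a modest move to a lower number is therefore expected, though a second limit remains possible. The expected step is an at least 2.0-fold lower number from compound 2 to compound 3 (0.30 log units; that floor lies within the scatter). Compound 3 is estimated at 5000 nM, with an expected range of 800 nM to 10000 nM.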

Compound 3, half-maximal inhibitory concentration: 4480 nM
Estimate against measurement, compound 3: 1.1-fold (0.05 log units) above; the range from low to high includes it.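

In this assay, the change on the amide-type nitrogen now has a readable size: 3-fluorophenyl in place of isobutyl gives an at least 2.2-fold lower number from compound 2 to compound 3 (0.34 log units; beyond the scatter), so this position responds to the group it carries. Going by these compounds alone, that size rests on a limit of the assay and not a number, the one held by compound 2: the limit of > 10000 nM in this assay, at which 1 of the 3 values shown sits. The (3-fluorophenyl)amino group and the piperidin-1-yl group on the carbonyl carbon cannot be told apart, with a 1.3-fold lower number from compound 1 to compound 3 (0.10 log units; within the scatter), so an aromatic ring on that nitrogen offers no measured gain over the piperidine amide.

From the compounds shown here alone, it remains open whether the fluorine itself contributes, which a plain phenyl ring on the same nitrogen would test. Also open, going by these compounds, is whether a benzyl group, or an aromatic ring carrying an amine or a carboxylic acid, would move the number further.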